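The source may report more compounds than this note shows. Statements on the series, on what has been measured and on what is new or still open speak of the compounds shown alone.

Among the measured compounds shown here, compound 2 `CCCCc1ccc(/C=C/C(=O)Nc2ccc3nc(CCC)cc(N)c3c2)cc1` stands at the weaker end of the two numbers so far: in an assay on isolated protein for displacement of a labelled ligand from melanin-concentrating hormone receptor 1 (Homo sapiens) (on this read-out lower numbers stand for stronger inhibition and higher numbers for weaker inhibition), compound 2 gives 45 nM, whereas compound 1 `CCCc1ccc(/C=C/C(=O)Nc2ccc3nc(CCC)cc(N)c3c2)cc1` gives 4 nM. Compound 3 `CCCc1cc(N)c2cc(NC(=O)/C=C/c3ccc(SC)cc3)ccc2n1` differs from compound 2 by methylsulfanyl in place of butyl on an aromatic carbon. For the measured compounds named here, the only measured step at this spot is an 11-fold higher number from compound 1 to compound 2 (1.05 log units; beyond the scatter), where the longer chain brought the higher number. Given an 11-fold higher number from compound 1 to compound 2 (1.05 log units; beyond the scatter) and that the group entering in compound 3 is the smaller one, compound 3 is expected to land below compound 2, though methylsulfanyl itself is untested here. The expected step for compound 3 is a 4.5-fold lower number from compound 2 to compound 3 (0.65 log units; beyond the scatter). The estimate for compound 3 in this assay is 10 nM, between 2.5 nM and 40 nM.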

Compound 3, half-maximal inhibitory concentration: 9 nM
For compound 3 the middle estimate is 1.1-fold (0.05 log units) above the measured one; measured number inside the range.
By their numbers in this assay, from the lowest: compound 1; then compound 3; then compound 2.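

In this assay, methylsulfanyl in place of butyl on the aromatic carbon gives a 5.0-fold lower number from compound 2 to compound 3 (0.70 log units; beyond the scatter), so a group holding sulfur is tolerated here, not only a plain carbon chain. Set against propyl, the same group gives a 2.3-fold higher number from compound 1 to compound 3 (0.35 log units; beyond the scatter), leaving compound 1 with the lowest number of the three. Nothing measured here explains these differences. As far as these compounds go, it remains open whether the sulfur matters or only the smaller group size. Ethyl or methoxy at this place would help separate the two, and plain hydrogen would show what any group adds.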